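A few compounds are considered here, and "the series" means these few. Any claim that something is new, unique, unknown or untested is made for them only; others in the source may bear on it.

Measured so far in a functional assay on A-375 cells (Homo sapiens) for antiproliferative activity, read by trypan blue exclusion, with a stated time of 48 h, tested at 1 uM; on this read-out lower numbers stand for a stronger effect and higher numbers for a weaker effect at the one concentration tested:
compound 1, `CCCCCCCCC#Cc1ccc(S(=O)(=O)Nc2cccc(-c3csc(NC(C)=O)n3)c2)cc1`, gives 39.6%
compound 2, `CC(=O)Nc1nc(-c2cccc(NS(=O)(=O)c3ccc(C#CCCc4ccccc4)cc3)c2)cs1`, gives 11.5%

Compound 2 stands lowest of the two numbers in this assay; its nearest neighbour is compound 1, whose number is higher, beyond the scatter. Compound 3, `CCCCCCc1ccc(S(=O)(=O)Nc2cccc(-c3csc(NC(C)=O)n3)c2)cc1`, is not yet measured. Its difference from compound 2 is hexyl in place of 4-phenylbut-1-yn-1-yl on an aromatic carbon. Going by the values given here, the only recorded step, a number 28.1 percentage points lower from compound 1 to compound 2 (beyond the scatter), concerns the chain end rather than the group on the aromatic carbon, so no measured step bears directly on this change. That step does show that the phenyl on the chain went with the lower number in this assay, and compound 3 loses that phenyl together with the triple bond. Therefore the step expected is a number 33.5 percentage points higher from compound 2 to compound 3 (beyond the scatter), toward a weaker effect. Compound 3 is expected to give 45% in this assay, within 20% to 75%. Nothing measured covers hexyl at the aromatic carbon, so the range is wide.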

Compound 3, a percentage reported as activity, at one concentration (the size of the read-out at that concentration, not a potency): 49.9%
The estimate for compound 3 lay 4.9 percentage points below the measured number, and the stated range covers the measured number.
By their numbers in this assay, from the lowest: compound 2; then compound 1; then compound 3.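

Hexyl in place of 4-phenylbut-1-yn-1-yl on an aromatic carbon para to a large group gives a number 38.4 percentage points higher from compound 2 to compound 3 (beyond the scatter) in this assay and hexyl in place of dec-1-yn-1-yl at the same place gives a number 10.3 percentage points higher from compound 1 to compound 3 (beyond the scatter) as the smaller of the two steps. Both groups with a triple bond therefore stand lower than hexyl on this read-out, and none of the three compounds goes against that order, while the larger step belongs to the group that also carries a phenyl ring. No measurement shown gives a reason for these differences.

Still open, on these data alone, is how much of the change follows the triple bond and how much the phenyl ring: 4-phenylbutyl and hex-1-yn-1-yl at this place would separate the two. As far as these compounds go, the effect of an amine or a carboxylic acid at the chain end also remains unknown.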